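This account rests on a few compounds, and the source may have more. Where it says the series, first, only, none or still open, it means among the compounds named here.

Measured compounds in an assay on CHO cells for displacement of a labelled ligand from adenosine receptor A3 (Homo sapiens), read by scintillation counting, with a stated time of 3 h; on this read-out lower numbers stand for stronger inhibition and higher numbers for weaker inhibition:
compound 1, `CCn1c(-c2ccccc2)nc2c(NC3CCC3)ncnc21`: 84 nM
compound 2, `CCn1c(-c2ccccc2)nc2c(NC3CCCC3)ncnc21`: 354 nM
compound 3, `CCn1c(-c2ccccc2)nc2c(N)ncnc21`: 5780 nM

Compound 3 gives the highest number of the three in this assay. Its nearest neighbour is compound 2, and the gap is a 16-fold higher number from compound 2 to compound 3 (1.21 log units; beyond the scatter); the gap to compound 1 is wider, a 69-fold higher number from compound 1 to compound 3 (1.84 log units; beyond the scatter). Among the measured compounds the only variable is the group on the ring nitrogen: cyclobutyl against cyclopentyl gives a 4.2-fold higher number from compound 1 to compound 2 (0.62 log units; beyond the scatter), and removing either ring group to leave hydrogen gives the larger steps already noted.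

Compound 4, `CCCn1c(-c2ccccc2)nc2c(N)ncnc21`, keeps the hydrogen on that nitrogen and instead alters the chain on the aromatic nitrogen: methyl in place of hydrogen on a saturated chain carbon, two bonds along the chain from an aromatic nitrogen. Read one bond further out this is methyl to ethyl, ethyl to propyl. Within the data shown here, none of the measured steps touches this chain, so nothing gauges the effect of lengthening it. The change is small, adds one carbon and no ring, donor or acceptor, and sits away from the nitrogen substituent that drives the measured steps. The expectation is therefore a step of a 1.1-fold lower number from compound 3 to compound 4 (0.02 log units; within the scatter), that is, no change beyond the scatter.

Compound 4 is estimated at 5500 nM in this assay, within a range of 2000 nM to 15000 nM.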

Compound 4, inhibition constant: 9280 nM
Beside the measured number, compound 4's estimate is 1.7-fold (0.23 log units) below it; the range from low to high includes it.
By their numbers in this assay, from the lowest: compound 1; then compound 2; then compounds 3 and 4 (each within the scatter of the next).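

In this assay, among these compounds, the first reading on the chain on the aromatic nitrogen, ethyl to propyl, gives a 1.6-fold higher number from compound 3 to compound 4 (0.21 log units; within the scatter), so adding methyl on a saturated chain carbon, two bonds along the chain from an aromatic nitrogen, does not separate these two compounds. Until now the series had varied only the group on the other nitrogen, where each step lay beyond the scatter, whereas this first step at the chain stays within it, at least when that other nitrogen carries hydrogen only. No measurement to hand accounts for the size of this step.

On these data alone, the result therefore covers a single chain extension on the unsubstituted amino compounds, and whether propyl behaves the same alongside the cyclobutyl group of compound 1 or the cyclopentyl group of compound 2 remains open. Also open, as far as these compounds go, is how far the chain can change at this position, for instance with a longer butyl chain, a branched isopropyl group or a benzyl group, and whether any of these would move the number beyond the scatter.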